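Bromo to methoxy on the aryl ring: racemic and enantiopure pairs

The source may hold more compounds than are shown below. What is called first, only, known or untested is meant among the compounds shown, and "the series" means these compounds.

Measured so far in a functional assay on HL-60 cells (Homo sapiens) for cytotoxicity, read by MTT assay, with a stated time of 48 h; on this read-out higher numbers stand for weaker inhibition and lower numbers for stronger inhibition:
compound 1, `C=C1C(=O)OC(C)CC1c1ccc(Br)cc1`, gives 4770 nM
compound 2, `C=C1C(=O)OC(C)CC1c1ccc(OC)cc1`, gives 5950 nM
compound 3, `C=C1C(=O)O[C@H](C)[C@@H]1c1ccc(Br)cc1`, gives 4280 nM

Compound 1 and compound 3 differ in their cores; that difference is not broken down here, and the two values sit within the scatter of each other. Compound 2 carries methoxy in place of bromo on an aromatic carbon relative to compound 1, and the step was a 1.2-fold higher number from compound 1 to compound 2 (0.10 log units; within the scatter) in this assay.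

Compound 4, `C=C1C(=O)O[C@H](C)[C@@H]1c1ccc(OC)cc1`, is not yet measured. It stands to compound 3 as compound 2 stands to compound 1, carrying (methoxy in place of bromo on an aromatic carbon). The place differs only in the size of the group para to the exchange, as the two difference descriptions show, so this is the same kind of change rather than the same change.

Resting on compound 1, whose step a 1.2-fold higher number from compound 1 to compound 2 (0.10 log units; within the scatter) stayed within the scatter, compound 4 is expected to show a step of about a 1.2-fold higher number from compound 3 to compound 4 (0.09 log units; within the scatter) from compound 3 in this assay. The estimate for compound 4 is therefore 5300 nM, expected between 3000 nM and 9500 nM.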

Compound 4, half-maximal inhibitory concentration: 4820 nM
The estimate for compound 4 lay 1.1-fold (0.04 log units) above the measured number, and the stated range covers the measured number.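

In this assay, methoxy in place of bromo on the aromatic carbon gives a 1.1-fold higher number from compound 3 to compound 4 (0.05 log units; within the scatter). Set beside the earlier step, the exchange reads alike on the two cores: the same change on two cores in this assay, a 1.2-fold higher number (0.10 log units; within the scatter) from compound 1 to compound 2 and a 1.1-fold higher number (0.05 log units; within the scatter) from compound 3 to compound 4, 1.1-fold (0.04 log units) apart, within the scatter of two such steps. This shows that on these two cores the exchange stays within the scatter in this cytotoxicity read-out, but with neither step distinguishable from scatter, the agreement is one of two small steps and does not show that a larger effect would carry from one core to the other, nor does one further pair make a rule for the series.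

The compounds shown hold only bromo and methoxy on the aromatic ring, so it remains open how an amine, a carboxylic acid or a longer chain such as butoxy would read at that place. Also open, going by these compounds, is whether the two cores would still read alike with such a group, where a step beyond the scatter could put the transfer to a real test.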